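From oxan-4-yl to methoxymethyl on a carbonyl carbon

A few compounds are considered here, and "the series" means these few. Any claim that something is new, unique, unknown or untested is made for them only; others in the source may bear on it.

- compound 1 `CCC(=O)N[C@@H](C)c1ccc(NC(=O)[C@H]2C[C@@H]2c2cccnc2)cc1` gives 5 nM
- compound 2 `C[C@H](NC(=O)CC(F)(F)F)c1ccc(NC(=O)[C@H]2C[C@@H]2c2cccnc2)cc1` gives 5 nM
- compound 3 `C[C@H](NC(=O)C1CCOCC1)c1ccc(NC(=O)[C@H]2C[C@@H]2c2cccnc2)cc1` gives 3 nM
- compound 4 `COCC(=O)N[C@@H](C)c1ccc(NC(=O)[C@H]2C[C@@H]2c2cccnc2)cc1` is not yet measured

In a functional assay on A2780 cells (Homo sapiens) for antiproliferative activity, read by CellTiter-Glo, with a stated time of 4 days (on this read-out higher numbers stand for weaker inhibition and lower numbers for stronger inhibition), compound 3 stands at 3 nM and lies within the scatter of the other two measured compounds. Compound 4 has methoxymethyl in place of oxan-4-yl on a carbonyl carbon. The measured exchanges at this carbon are small: a 1.7-fold lower number from compound 1 to compound 3 (0.22 log units; within the scatter) and a 1.7-fold lower number from compound 2 to compound 3 (0.22 log units; within the scatter) are both within the scatter, as is no change at the digits printed from compound 1 to compound 2 (within the scatter) in the chain of compound 1. No step beyond the scatter is therefore expected in this assay for this change. The expected change is small (a 1.3-fold higher number from compound 3 to compound 4 (0.12 log units; within the scatter)) and stays within the scatter. The estimate for compound 4 is an expected 4 nM (range 2 nM to 10 nM).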

Compound 4, half-maximal inhibitory concentration: 30 nM
Compound 4: middle estimate off by 7.5-fold (0.88 log units), on the low side, and the stated range ends below it.
By their numbers in this assay, from the lowest: compounds 3, 1 and 2 (each within the scatter of the next); then compound 4.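

At this carbonyl carbon, this assay shows that the position is not as indifferent as the first three compounds suggested: methoxymethyl in place of oxan-4-yl gives a 10-fold higher number from compound 3 to compound 4 (1.00 log units; beyond the scatter) and stands beyond the scatter. Methoxy in place of methyl gives a 6.0-fold higher number from compound 1 to compound 4 (0.78 log units; beyond the scatter) and methoxy in place of trifluoromethyl gives a 6.0-fold higher number from compound 2 to compound 4 (0.78 log units; beyond the scatter) on the same chain carbon, so this exchange separates compound 4 from all three earlier compounds. No measurement here accounts for the step. On these data alone, whether a longer chain such as 2-methoxyethyl, an amine or a carboxylic acid at this carbon would stay with compounds 1 to 3 or with compound 4 remains open.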